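A few compounds are considered here, and "the series" means these few. Any claim that something is new, unique, unknown or untested is made for them only; others in the source may bear on it.

Measured compounds:
- Compound 1, `C/C(=C\c1cc(-c2cccnc2)co1)C(N)=O`. In a functional assay on T-24 cells (Homo sapiens) for cytotoxicity, read by CCK-8 assay, with a stated time of 24 h (a higher number here means a weaker inhibitor, a lower number a stronger inhibitor), compound 1 gives > 50000 nM, which is a limit of the assay and not a number.
- Compound 2, `C/C(=C\c1ccc(-c2ccc(C)cc2)o1)C(N)=O`. In this assay compound 2 gives > 50000 nM, again a limit.
- Compound 3, `C/C(=C\c1nc(-c2ccccc2)cs1)C(N)=O`. In this assay compound 3 gives > 50000 nM, also a limit.

Compound 3 thus stands where every measured compound stands: at the limit of > 50000 nM in this assay, at which 3 of the 3 values shown sit. Among the compounds with values here, no number separates it from compound 1 or compound 2, and no step between measured compounds can be drawn, so the measured data give no sense of how large a change in this assay a small structural alteration produces.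

The unmeasured compound 4, `C/C(=C\c1nc(-c2ccc(F)cc2)cs1)C(N)=O`, differs from compound 3 in one respect: fluoro in place of hydrogen on an aromatic carbon, on an aromatic carbon of a six-membered aromatic ring of carbon only, para to a large group. Since all values shown sit at the limit, the expectation is that this step brings no shift beyond the scatter, and compound 4 is estimated to stay at the limit as well, with the step from compound 3 to compound 4 expected at a number no higher from compound 3 to compound 4 (the limit leaves the size open). Compound 4 is therefore estimated at 50000 nM, within a range from 15000 nM to 200000 nM.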

Compound 4, half-maximal inhibitory concentration: > 50000 nM
Compound 4 gave a limit, no number; the forecaster's own chance of this, stated with the estimate: 80%; the middle value sits exactly at the limit.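

Within the data shown here, compound 3 and compound 4 each give only a limit in this assay and not a number, so the swap of hydrogen for fluoro yields no step that can be read. The compounds shown leave open whether any change to the shared core would bring a measurable value, as all of them stand at one limit: the limit of > 50000 nM in this assay, at which 4 of the 4 values shown sit.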